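Swapping Bromo for Methoxycarbonyl on an Indazole-Type Core

The source may report more compounds than this note shows. Statements on the series, on what has been measured and on what is new or still open speak of the compounds shown alone.

Compound 2 `O=[N+]([O-])c1ccccc1CNc1cc(Br)cc2[nH]ncc12` is one of a small group of compounds tested in an assay for inhibition of Tryptophan 2,3-dioxygenase (Homo sapiens), with stated times of 10 min and 60 min (a lower number here means a stronger inhibitor, a higher number a weaker inhibitor), a test in which compound 2 gives 39000 nM. Among the two numbers available, that of compound 2 is the highest, meaning the weaker inhibitor. Its nearest neighbour is compound 3 `O=[N+]([O-])c1ccc(O)cc1CNc1cc(Br)cc2[nH]ncc12`, which gives 460 nM in this assay. Compound 1 `NCCn1ncc2c(NCc3ccccc3[N+](=O)[O-])cc(C(F)(F)F)cc21` yields only a limit in this assay, > 100000 nM, and not a number (the limit of > 100000 nM in this assay, at which 1 of the 3 values shown sits). Within the data shown here, the one step that can be measured runs from compound 2 to compound 3, where hydroxy replaces hydrogen on an aromatic carbon and the number falls by an 85-fold lower number from compound 2 to compound 3 (1.93 log units; beyond the scatter).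

Compound 4 `COC(=O)c1cc(NCc2ccccc2[N+](=O)[O-])c2cn[nH]c2c1` has not yet been measured. It differs from compound 2 as follows: methoxycarbonyl in place of bromo on an aromatic carbon. Among the measured compounds shown here, no measured step touches the position where bromo sits, so the large change from compound 2 to compound 3 does not bear directly on this swap. Without any comparable precedent, the expectation is a step of a 1.0-fold higher number from compound 2 to compound 4 (0.01 log units; within the scatter), that is, no change beyond the scatter. Compound 4 is therefore estimated to give 40000 nM in this assay, with a range from 8000 nM to 200000 nM.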

Compound 4, half-maximal inhibitory concentration: > 100000 nM
Compound 4 ended at the assay's limit; the forecaster's own chance of this, stated with the estimate: 30%; middle value at least 2.5-fold (0.39 log units) from the limit.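

The swap on the aromatic carbon that carries bromo in compound 2 gives an at least 2.5-fold higher number from compound 2 to compound 4 (0.40 log units; beyond the scatter) in this assay. Among these compounds, this is the first measured step at this position, and it shows that the position is not indifferent to the group placed there, even though the shared core and the nitro-bearing ring stay the same. Compound 4 gives > 100000 nM, which is a limit of the assay and not a number, so this step has no exact size: the limit of > 100000 nM in this assay, at which 2 of the 4 values shown sit.

With only this one swap at the position, the compounds shown cannot separate the effect of the larger group from that of the added hydrogen-bond acceptors, since methoxycarbonyl differs from bromo in both counts. Going by these compounds, it also remains open how a small group such as chloro or methyl, or a carboxylic acid or an amide, would fare on this carbon, and whether the hydroxy group that separates compound 3 from compound 2 would bring a similar gain with methoxycarbonyl in place of bromo.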